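Adding a Second Chlorine to a Purine-Type Core

The source may hold more compounds than are shown below. What is called first, only, known or untested is meant among the compounds shown, and "the series" means these compounds.

Compound 2 `ClCc1ccccc1Cn1cnc2ncnc(Cl)c21` and compound 1 `ClCc1ccccc1Cn1cnc2c(Cl)nc(Cl)nc21` share a chloromethylbenzyl arm on a fused two-ring core. In a functional assay on UACC-62 cells (Homo sapiens) for cytotoxicity, read by sulforhodamine B assay, with a stated time of 48 h (a lower number here means a stronger inhibitor of growth, a higher number a weaker inhibitor of growth), compound 1 gives 1310 nM, and compound 2 gives 1860 nM; these two numbers cannot be told apart within the usual scatter of such measurements. Compound 3 `ClCc1ccccc1Cn1cnc2nc(Cl)nc(Cl)c21` has not yet been tested in this assay. It differs from compound 2 by chloro in place of hydrogen on an aromatic carbon. Among the measured compounds shown here, no measured pair here tracks that change, so no step beyond the scatter is expected from compound 2 to compound 3 in this assay. Compound 3 is therefore expected to give about 1400 nM, within 600 nM to 3500 nM, a change of a 1.3-fold lower number from compound 2 to compound 3 (0.12 log units; within the scatter).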

Compound 3, concentration for 50% growth inhibition: 1200 nM
For compound 3 the middle estimate is 1.2-fold (0.07 log units) above the measured one; the measured number falls inside the stated range.
By their numbers in this assay, from the lowest: compounds 3, 1 and 2 (each within the scatter of the next).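

Placing chloro in place of hydrogen on an aromatic carbon between two ring nitrogen atoms gives a 1.6-fold lower number from compound 2 to compound 3 (0.19 log units; within the scatter) in this assay. Among the compounds shown here, this is the first direct test of this position, and it shows that the ring carbon can carry a chlorine with no change that can be told from the scatter. No measurement here gives a reason for this result. On these data alone, whether a larger group at this position, such as an amine or a methoxy group, would leave growth inhibition just as unchanged stays open.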